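Methyl on the phenyl of compound 3: expected outcome

A few compounds are considered here, and "the series" means these few. Any claim that something is new, unique, unknown or untested is made for them only; others in the source may bear on it.

Compound 3 `O=C(Nc1ccc(Oc2ccnc3[nH]ccc23)cc1)c1cc(-c2ccccc2)ncn1` stands at the lowest number of the three measured compounds in a functional assay on A549 cells (Homo sapiens) for cytotoxicity, read by MTT assay, with a stated time of 72 h; on this read-out lower numbers stand for stronger inhibition and higher numbers for weaker inhibition; in this assay compound 3 gives 140 nM. Its nearest neighbour is compound 1 `O=C(Nc1ccc(Oc2ccnc3[nH]ccc23)cc1)c1cc(-c2ccc(Cl)cc2)ncn1`, which gives 6530 nM, and the furthest is compound 2 `O=C(Nc1ccc(Oc2ccnc3[nH]ccc23)cc1)c1cc(-c2ccc(C(F)(F)F)cc2)ncn1`, which gives 9380 nM. Both of these carry a group on the phenyl where compound 3 carries hydrogen, and the two steps that remove that group are a 47-fold lower number from compound 1 to compound 3 (1.67 log units; beyond the scatter) and a 67-fold lower number from compound 2 to compound 3 (1.83 log units; beyond the scatter). Between the two substituted compounds the step is a 1.4-fold higher number from compound 1 to compound 2 (0.16 log units; within the scatter), so the chloro and trifluoromethyl compounds sit together, far from the unsubstituted one.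

Compound 4 `Cc1ccc(-c2cc(C(=O)Nc3ccc(Oc4ccnc5[nH]ccc45)cc3)ncn2)cc1` differs from compound 3 by methyl in place of hydrogen on an aromatic carbon. The bearing steps are the two just named: each time a group entered at this place the number rose by a large amount, and the two groups, though different, gave nearly the same result. Methyl is a third group at the same place, and no measured step tells whether it behaves like the other two. The step is therefore expected to be an 11-fold higher number from compound 3 to compound 4 (1.03 log units; beyond the scatter), a rise smaller than the two measured ones. Compound 4 is estimated at 1500 nM, with a range from 300 nM to 8000 nM.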

Compound 4, half-maximal inhibitory concentration: 5410 nM
Compound 4: the middle estimate sits 3.6-fold (0.56 log units) below what was measured; the measured number falls inside the stated range.
By their numbers in this assay, from the lowest: compound 3; then compounds 4, 1 and 2 (each within the scatter of the next).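

In this assay, methyl para to a large group acts as chloro and trifluoromethyl do: the change gives a 39-fold higher number from compound 3 to compound 4 (1.59 log units; beyond the scatter), a large step of the same kind as the two seen before, so the earlier rise is not confined to those two groups. Among the compounds shown here, the three substituted compounds cannot be told apart on these numbers, since the series shows a 1.7-fold lower number from compound 2 to compound 4 (0.24 log units; within the scatter) and a 1.2-fold lower number from compound 1 to compound 4 (0.08 log units; within the scatter), both within the usual scatter, leaving hydrogen as the only group at this place that gives a number far lower than the others, with no compound among the four going against this. Nothing on hand gives a reason for this shared step.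

Still open, on these data alone, is whether any other group at this place keeps the number near that of compound 3, with fluoro, hydroxy, methoxy, an amine or a carboxylic acid as the obvious next readings. Also open, as far as these compounds go, is whether methyl on another carbon of the phenyl gives the same large step, and whether the step reflects anything beyond cytotoxicity in this one cell line.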